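Shorter Tether, Same Reading: Compound 4 in Hexokinase-3 Inhibition

The source may report more compounds than this note shows. Statements on the series, on what has been measured and on what is new or still open speak of the compounds shown alone.

Measured so far:
compound 1 `Nc1ncnc2c1nc(NCCCCCCCCNC(=O)CI)n2[C@@H]1O[C@H](COP(=O)(O)OP(=O)(O)OP(=O)(O)O)[C@@H](O)[C@H]1O`: 0%
compound 2 `O=C(CI)NCCCCC(=O)NCCCCCCNc1ncnc2c1ncn2[C@@H]1O[C@H](COP(=O)(O)OP(=O)(O)OP(=O)(O)O)[C@@H](O)[C@H]1O`: 0%
compound 3 `O=C(CI)NCCCCCCC(=O)NCCCNc1ncnc2c1ncn2[C@@H]1O[C@H](COP(=O)(O)OP(=O)(O)OP(=O)(O)O)[C@@H](O)[C@H]1O`: 0%

In an assay on isolated protein for inhibition of hexokinase-3 (Rattus norvegicus), with a stated time of 6 h, tested at 10 mM (on this read-out higher numbers stand for more inhibition at the one concentration tested (going by the name of the read-out) and lower numbers for less inhibition), compound 1 gives 0%. Compound 2 gives 0% in this assay, and compound 3 gives 0%. Compound 1 thus stands level with compounds 2 and 3 at the digits reported; its nearest neighbour is compound 2 and its furthest is compound 3, and in both cases there is no change at the digits reported, which lies within the scatter. None of the three compounds shows any inhibition in this assay, so the three values carry no information about which structural features matter.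

Compound 4 `Nc1ncnc2c1nc(NCCNC(=O)CI)n2[C@@H]1O[C@H](COP(=O)(O)OP(=O)(O)OP(=O)(O)O)[C@@H](O)[C@H]1O` differs from compound 1 in a single place: ((iodomethyl)carbonyl)amino in place of 6-(((iodomethyl)carbonyl)amino)hexyl on a saturated chain carbon, two bonds along the chain from a nitrogen on an aromatic ring. Within the data shown here, no step between two measured compounds is available, so nothing about the size or direction of such a change can be read from the data. The expectation for this assay is therefore a step of none beyond the scatter, estimated as no change at the digits printed from compound 1 to compound 4 (within the scatter). With compound 1 giving 0% and its two relatives sitting at the same reading, compound 4 is estimated to give 0% in this assay, with a range from 0% to 10%.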

Compound 4, a percentage reported as inhibition, at one concentration (the size of the read-out at that concentration, not a potency): 0%
Beside the measured number, compound 4's estimate shows no gap at the digits printed; the measured number falls inside the stated range.
By their numbers in this assay, from the lowest: compounds 1, 2, 3 and 4 (each within the scatter of the next).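

In this assay, replacing 6-(((iodomethyl)carbonyl)amino)hexyl with ((iodomethyl)carbonyl)amino on a saturated chain carbon, two bonds along the chain from a nitrogen on an aromatic ring, gives no change at the digits printed from compound 1 to compound 4 (within the scatter). Among these compounds, this is the first direct comparison at this position, and it shows that the 5-heavy-atom group and the 11-heavy-atom group give the same reading, with no inhibition from either one. Since both compounds sit at the same reading of no inhibition, the pair shows no effect of tether length over this span, and no measured evidence offers an explanation for that flat result.

Still open, on these data alone, is whether any group at this position can produce a reading above that of compound 1, for instance an amine or a carboxylic acid in place of ((iodomethyl)carbonyl)amino. Also open, as far as these compounds go, is whether a longer chain than the hexyl tether of compound 1, or a different group on the shared core, would give measurable inhibition.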